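From a 4-fluorobenzyl arm to an (ethoxycarbonyl)methyl arm

A few compounds are considered here, and "the series" means these few. Any claim that something is new, unique, unknown or untested is made for them only; others in the source may bear on it.

Compound 2 `CNc1cc(-c2ccc3cnn(Cc4ccc(F)cc4)c3c2)cn(C)c1=O` gives 2390 nM in a functional assay on MV4-11 cells (Homo sapiens) for antiproliferative activity, read by luminescence and CellTiter-Glo, with a stated time of 72 h (a higher number here means a weaker inhibitor, a lower number a stronger inhibitor), the lowest of the three numbers in hand. Its nearest neighbour, compound 3 `CCNc1cc(-c2ccc3cnn(Cc4ccc(F)cc4)c3c2)cn(C)c1=O`, gives 5650 nM, and the step of a 2.4-fold higher number from compound 2 to compound 3 (0.37 log units; beyond the scatter) comes from a methyl in place of hydrogen on a saturated chain carbon bound to a nitrogen on an aromatic ring. Compound 1 `COc1ccc(Cn2nc(Nc3cccc(C(C)C)c3)c3ccc(-c4c(C)noc4C)cc32)cc1`, on a different core, gives 8100 nM. Compound 4 `CCOC(=O)Cn1ncc2ccc(-c3cc(NC)c(=O)n(C)c3)cc21` differs from compound 2 by ethoxycarbonyl in place of 4-fluorophenyl on a saturated chain carbon bound to an aromatic nitrogen. Going by the values given here, no measured step touches this part of the molecule, so nothing in hand sets the size or direction of the change, and the uncertainty is wide. Compound 4 is expected to give about 8000 nM, somewhere between 2000 nM and 30000 nM. That estimate means a step of a 3.3-fold higher number from compound 2 to compound 4 (0.52 log units; beyond the scatter).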

Compound 4, half-maximal inhibitory concentration: 8770 nM
Compound 4: middle estimate off by 1.1-fold (0.04 log units), on the low side; the range from low to high includes it.
By their numbers in this assay, from the lowest: compound 2; then compounds 3, 1 and 4 (each within the scatter of the next).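

In this assay, the first change measured at this arm gives a 3.7-fold higher number from compound 2 to compound 4 (0.56 log units; beyond the scatter), so replacing 4-fluorophenyl with ethoxycarbonyl on the saturated chain carbon weakens the compound only modestly. Going by these compounds alone, a ring-free arm carrying two hydrogen-bond acceptors therefore still gives a measurable number, although the single step cannot separate losing the ring from adding the ester. No measurement in hand explains the step. From the compounds shown here alone, how a carboxylic acid, a primary amide or a plain benzyl group would behave here remains open.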